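This account rests on a few compounds, and the source may have more. Where it says the series, first, only, none or still open, it means among the compounds named here.

Measured so far:
Compound 1 `COc1ccc(Cn2nnc(O)c2C(=O)Nc2cccc(-c3ccccc3)c2)cc1`: 52100 nM
Compound 2 `COc1ccc(Cn2nnc(O)c2C(=O)Nc2cccc(-c3ccc(OC)cc3)c2)cc1`: 50100 nM

Both compounds were tested in a functional assay on CWR22R cells (Homo sapiens) for inhibition, read by sulforhodamine B assay, with a stated time of 72 h; on this read-out lower numbers stand for stronger inhibition and higher numbers for weaker inhibition. With only these two numbers available, compound 2 stands within the scatter of compound 1, so neither can be ranked above the other. The next compound, compound 3 `COc1ccc(Cn2nnc(O)c2C(=O)Nc2cccc(-c3cccc(OC)c3)c2)cc1`, has not yet been measured. It differs from compound 2 by 3-methoxyphenyl in place of 4-methoxyphenyl on an aromatic carbon, meta to a large group.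

Within the data shown here, only one measured step bears on this change. It is methoxy in place of hydrogen on an aromatic carbon, and it gave a 1.0-fold lower number from compound 1 to compound 2 (0.02 log units; within the scatter). Among the measured compounds shown here, no measured pair shows directly what relocating the methoxy does, so this evidence is indirect. Since the step of a 1.0-fold lower number from compound 1 to compound 2 (0.02 log units; within the scatter) stayed within the scatter, no change beyond the scatter is expected in this assay, and no direction is favoured. The expected step is a 1.0-fold lower number from compound 2 to compound 3 (0.00 log units; within the scatter). For compound 3 the estimated value is 50000 nM, with an expected range from 25000 nM to 95000 nM.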

Compound 3, half-maximal inhibitory concentration: 59000 nM
Compound 3: the middle estimate sits 1.2-fold (0.07 log units) below what was measured; the range from low to high includes it.
By their numbers in this assay, from the lowest: compounds 2, 1 and 3 (each within the scatter of the next).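

In this assay, among these compounds, putting 3-methoxyphenyl in place of 4-methoxyphenyl gave a step that can be read directly for the first time (from a 1.2-fold higher number from compound 2 to compound 3 (0.07 log units; within the scatter)), and it shows that these two placements of the methoxy cannot be told apart on this read-out. The step for adding methoxy at the newly tested place (from a 1.1-fold higher number from compound 1 to compound 3 (0.05 log units; within the scatter)) likewise stays within the scatter, so compound 3 joins compound 2 in reading alike with the unsubstituted phenyl of compound 1, and neither the presence of the methoxy nor its place separates these three compounds. No supporting data are available to explain why the three compounds read alike.

The compounds shown leave open whether any other group on this aromatic ring, such as an amine, a carboxylic acid or a longer chain like butoxy, would give a step beyond the scatter. They also leave open whether changing another part of the shared core, such as the 4-methoxybenzyl group or the amide hydrogen, would move the number in this assay at all.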